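Sulfonyl sulfur exchanges: compound 3 to compound 4

This account rests on a few compounds, and the source may have more. Where it says the series, first, only, none or still open, it means among the compounds named here.

Measured in a functional assay on DU-145 cells (Homo sapiens) for inhibition, read by trypan blue exclusion, with a stated time of 72 h; on this read-out lower numbers stand for stronger inhibition and higher numbers for weaker inhibition:
- compound 1 `Cn1c(=O)c(S(=O)(=O)Cc2ccc(F)cc2F)cc2cnc(Nc3ccc4[nH]ccc4c3)nc21`: 1000 nM
- compound 2 `COc1ccc(S(=O)(=O)c2cc3cnc(Nc4ccc5[nH]ccc5c4)nc3n(C)c2=O)cc1`: 500 nM
- compound 3 `Cc1ccc(S(=O)(=O)c2cc3cnc(Nc4ccc5[nH]ccc5c4)nc3n(C)c2=O)cc1`: 750 nM

Compound 3 stands within the scatter of both other compounds, with a 1.3-fold lower number from compound 1 to compound 3 (0.12 log units; within the scatter) and a 1.5-fold higher number from compound 2 to compound 3 (0.18 log units; within the scatter). Compound 4 `Cn1c(=O)c(S(=O)(=O)Nc2ccc(F)cc2F)cc2cnc(Nc3ccc4[nH]ccc4c3)nc21` carries (2,4-difluorophenyl)amino in place of 4-methylphenyl on a sulfonyl sulfur.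

The closest evidence comes from the other exchanges on that sulfur. These are a 2.0-fold lower number from compound 1 to compound 2 (0.30 log units; within the scatter) and the step to compound 3 already given. The change on the aromatic carbon of the sulfonyl substituent, a 1.5-fold higher number from compound 2 to compound 3 (0.18 log units; within the scatter), is also small. All of these steps stay within the scatter, and the three values form a narrow group. Compound 1, which carries 2,4-difluorobenzyl on the sulfur, gives 1000 nM. Among the compounds with values here, no measured compound has an amino group on the sulfonyl sulfur, so this evidence is indirect and the range is kept wide.

No step beyond the scatter is expected in this assay, and no direction is favoured. The expected step is a 1.1-fold lower number from compound 3 to compound 4 (0.03 log units; within the scatter). For compound 4 the estimated value is 700 nM, with an expected range from 250 nM to 2000 nM.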

Compound 4, half-maximal inhibitory concentration: 5000 nM
Beside the measured number, compound 4's estimate is 7.1-fold (0.85 log units) below it, and the stated range ends below it.
By their numbers in this assay, from the lowest: compounds 2, 3 and 1 (each within the scatter of the next); then compound 4.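

In this assay, the sulfonyl sulfur no longer looks like a tolerant position: with (2,4-difluorophenyl)amino on it, the series shows a 6.7-fold higher number from compound 3 to compound 4 (0.82 log units; beyond the scatter) and a 10-fold higher number from compound 2 to compound 4 (1.00 log units; beyond the scatter), whereas the exchanges among the 4-methylphenyl, 4-methoxyphenyl and 2,4-difluorobenzyl groups all stayed within the scatter. The most telling comparison is a 5.0-fold higher number from compound 1 to compound 4 (0.70 log units; beyond the scatter), since a 2,4-difluorinated phenyl ring is present on both sides, so the presence of that ring does not by itself set compound 4 apart, and the change lies in the amino link that replaces the benzyl carbon. The entering group also counts a hydrogen-bond donor where the groups on compounds 1, 2 and 3 have none on that link, but nothing available here ties the weaker inhibition to that donor or to any other feature of the group.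

From the compounds shown here alone, it remains open whether the amino hydrogen matters or the amino link as a whole does, a question that an N-methyl-N-(2,4-difluorophenyl)amino group on the same sulfur would address. A plain phenylamino group would likewise show whether the two fluorines contribute once the amino link is present.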